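The source may hold more compounds than are shown below. What is called first, only, known or untested is meant among the compounds shown, and "the series" means these compounds.

In a functional assay on K562 cells (Homo sapiens) for antiproliferative activity, read by MTT assay, with a stated time of 48 h (on this read-out lower numbers stand for stronger inhibition and higher numbers for weaker inhibition), compound 1 `N#Cc1nc2c(-c3nc4ccccc4[nH]3)c(N)n(CCN3CCCC3)c2nc1C#N` gives 6480 nM on the shared core. The value of compound 2 `N#Cc1nc2c(-c3nc4ccccc4[nH]3)c(N)n(CCO)c2nc1C#N` is > 50000 nM as a limit of the assay. Within the data shown here, compound 3 `CCN(CC)CCCCn1c(N)c(-c2nc3ccccc3[nH]2)c2nc(C#N)c(C#N)nc21` gives 1440 nM as the lowest number so far. Compound 4 `CCN(CC)CCCCn1c(N)c(-c2nc3cc(Cl)ccc3[nH]2)c2nc(C#N)c(C#N)nc21` differs from compound 3 by chloro in place of hydrogen on an aromatic carbon in the change from 1H-benzimidazol-2-yl to 5-chloro-1H-benzimidazol-2-yl. The measured steps of an at least 7.7-fold higher number from compound 1 to compound 2 (0.88 log units; beyond the scatter) and a 4.5-fold lower number from compound 1 to compound 3 (0.65 log units; beyond the scatter) and an at least 34-fold lower number from compound 2 to compound 3 (1.54 log units; beyond the scatter) all lie on the saturated chain, and none touches this aromatic carbon. The starting point is compound 3 at 1440 nM. No step beyond the scatter is therefore expected in this assay from compound 3, with any drift toward a lower number. The estimated move is a 1.4-fold lower number from compound 3 to compound 4 (0.16 log units; within the scatter) on this basis. Compound 4 is expected at 1000 nM within 350 nM to 3000 nM in this estimate.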

Compound 4, half-maximal inhibitory concentration: 1270 nM
Estimate against measurement, compound 4: 1.3-fold (0.10 log units) below; the range from low to high includes it.
By their numbers in this assay, from the lowest: compounds 4 and 3 (each within the scatter of the next); then compound 1. At a limit, above all of these: compound 2.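

In this assay, a 1.1-fold lower number from compound 3 to compound 4 (0.05 log units; within the scatter) is the first step shown on an aromatic carbon of the six-membered aromatic ring of carbon only; all earlier steps lie on the saturated chain. Chloro in place of hydrogen at this position therefore gives no difference beyond the scatter on the longer diethylamino chain. Nothing measured here bears on the reason for this result.

From the compounds shown here alone, whether methoxy, trifluoromethyl or an amine on this aromatic carbon would move the number stays open. So does whether chloro reads the same with the pyrrolidin-1-yl chain of compound 1.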